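A few compounds are considered here, and "the series" means these few. Any claim that something is new, unique, unknown or untested is made for them only; others in the source may bear on it.

The measured compounds:

compound 1, `O=C(O)c1ccc(NCc2cccc(Oc3ccccc3)c2)cc1`: 86%
compound 2, `Cc1nc(-c2ccc(C(F)(F)F)cc2)sc1CNc1ccc(/C=C/C(=O)O)cc1`: 95%
compound 3, `Cc1nc(-c2ccc(C(F)(F)F)cc2)sc1CNc1ccc(OCC(=O)O)cc1`: 100%

All three were tested in a functional assay on CHO cells for agonist activity at Free fatty acid receptor 1 (Homo sapiens), read by a luciferase reporter; a lower number here means a smaller maximal response, a higher number a larger maximal response. On these numbers compound 1 gives the lowest of the three values, yet the value of compound 2 lies within the scatter of it, and only compound 3 stands beyond the scatter above compound 1. Among the measured compounds shown here, the only single-point step among the measured compounds is the one from compound 2 to compound 3, a change of the acid-bearing group on a different core, which gave a number 5 percentage points higher from compound 2 to compound 3 (within the scatter).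

Compound 4, `CC(CC(=O)O)c1ccc(NCc2cccc(Oc3ccccc3)c2)cc1`, arises from compound 1 through (1-(carboxymethyl)ethyl in place of carboxy on an aromatic carbon). For the measured compounds named here, no measured pair carries this exact change, so the account rests on the one step that does alter the acid-bearing group: since that step from compound 2 to compound 3 stayed within the scatter, a comparable change on the core of compound 1 is expected to leave the maximal response essentially where it is, with at most a small upward drift, so that the step from compound 1 to compound 4 is estimated as a number 6 percentage points higher from compound 1 to compound 4 (within the scatter). For compound 4 in this assay the expected value is therefore 92%, with a range from 80% to 104%.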

Compound 4, largest response reached (reported as percent of maximum), in percent of the reference or control that the assay uses: 83%
Beside the measured number, compound 4's estimate is 9 percentage points above it; low and high end bracket the measured number.
By their numbers in this assay, from the lowest: compounds 4, 1, 2 and 3 (each within the scatter of the next, the first and the last beyond it).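

In this assay, among the compounds shown here, the result gives a first reading at this position on the core of compound 1: with 1-(carboxymethyl)ethyl in place of carboxy on the aromatic carbon para to a large group, the step is a number 3 percentage points lower from compound 1 to compound 4 (within the scatter). The acid-bearing group here grows from 3 to 6 heavy atoms and its carboxylic acid no longer stands directly on the ring, yet the two maximal responses cannot be told apart. The step from compound 2 to compound 3 showed only an exchange of one acid-bearing chain for another on a different core, so this is the first sign that the core of compound 1 also tolerates such a replacement, and nothing shown accounts for this outcome.

As far as these compounds go, whether the same reading would hold for an unbranched 2-carboxyethyl chain, or for a primary amide in place of the carboxylic acid at this position, remains open. From the compounds shown here alone, the read-out is also the largest response alone, so how much of each compound is needed to reach that response stays unknown.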